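Ortho-substituent change on the benzylic aryl: methoxy to phenyl

A few compounds are considered here, and "the series" means these few. Any claim that something is new, unique, unknown or untested is made for them only; others in the source may bear on it.

Measured compounds:
compound 1, `CC(C)C[C@@H]1C(=O)N[C@H](C2Cc3ccccc3C2)C(=O)N1[C@@H](C(=O)NC(C)C)c1ccccc1C(F)(F)F`, 31.6 nM
compound 2, `COc1ccccc1[C@H](C(=O)NC(C)C)N1C(=O)[C@@H](C2Cc3ccccc3C2)NC(=O)[C@H]1CC(C)C`, 31.6 nM
compound 3, `COC(=O)c1ccccc1[C@@H](C(=O)NC(C)C)N1C(=O)[C@@H](C2Cc3ccccc3C2)NC(=O)[C@H]1CC(C)C`, 158 nM

In an assay on isolated protein for antagonist activity at Oxytocin receptor (Homo sapiens), read by FLIPR (on this read-out higher numbers stand for weaker inhibition and lower numbers for stronger inhibition), compound 2 gives 31.6 nM, level with compound 1 at the digits shown and together with it the lowest of the three numbers. The step of no change at the digits printed from compound 1 to compound 2 (within the scatter) shows that exchanging trifluoromethyl for methoxy at this position leaves the number unchanged within the scatter. Compound 3, with a methoxycarbonyl at the same place, gives 158 nM, a clearly higher number than compound 2.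

Compound 4, `CC(C)C[C@@H]1C(=O)N[C@H](C2Cc3ccccc3C2)C(=O)N1[C@@H](C(=O)NC(C)C)c1ccccc1-c1ccccc1`, differs from compound 2 by phenyl in place of methoxy on an aromatic carbon. Within the data shown here, no measured step covers a phenyl here; the one measured step shows a small group swap with no effect, while compound 3 shows that another group at this position can raise the number. Compound 4 is therefore expected to give 80 nM (range 25 nM to 300 nM) in this assay, the expected step being a 2.5-fold higher number from compound 2 to compound 4 (0.40 log units; beyond the scatter), a modest move toward weaker inhibition.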

Compound 4, inhibition constant: 39.8 nM
Beside the measured number, compound 4's estimate is 2.0-fold (0.30 log units) above it; the measured number falls inside the stated range.
By their numbers in this assay, from the lowest: compounds 1, 2 and 4 (each within the scatter of the next); then compound 3.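

Phenyl in place of methoxy gives a 1.3-fold higher number from compound 2 to compound 4 (0.10 log units; within the scatter) in this assay, so this aromatic carbon takes a six-membered aromatic ring of carbon only with no change beyond the scatter. Phenyl in place of trifluoromethyl reads the same way, a 1.3-fold higher number from compound 1 to compound 4 (0.10 log units; within the scatter), so compounds 1, 2 and 4 cannot be told apart here, although the entering phenyl has more heavy atoms than the methoxy it replaces. Among the four compounds, only compound 3, with its methoxycarbonyl, at 158 nM, stands apart from this level reading.

Nothing shown gives a measured reason for these results. Going by these compounds, it remains open whether an amine or a carboxylic acid at this place would keep the number level or raise it, as the methoxycarbonyl of compound 3 does.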